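Aryl amines on the shared core: outlook for compound 3

This account rests on a few compounds, and the source may have more. Where it says the series, first, only, none or still open, it means among the compounds named here.

Measured so far:
compound 1, `CCCCCCCCNc1nc(SCc2ccc(C(F)(F)F)cc2)nc2ccccc12`, 10500 nM
compound 2, `FC(F)(F)c1ccc(CSc2nc(Nc3cccc(Br)c3)c3ccccc3n2)cc1`, 8680 nM

Both numbers come from a functional assay on PC-3 cells (Homo sapiens) for cytotoxicity, read by MTT assay, with a stated time of 72 h; a higher number here means a weaker inhibitor, a lower number a stronger inhibitor. Compound 2 gives 8680 nM in this assay and compound 1 gives 10500 nM; the step of a 1.2-fold lower number from compound 1 to compound 2 (0.08 log units; within the scatter) is the only one in hand, and it lies within the scatter, so the two compounds are not told apart.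

Compound 3, `O=[N+]([O-])c1ccc(Nc2nc(SCc3ccc(C(F)(F)F)cc3)nc3ccccc23)cc1`, is not yet measured. It differs from compound 2 by 4-nitrophenyl in place of 3-bromophenyl on a nitrogen on an aromatic ring. Among the measured compounds shown here, no measured step changes one aryl group on this nitrogen for another; the single step on this position, a 1.2-fold lower number from compound 1 to compound 2 (0.08 log units; within the scatter), swapped octyl for 3-bromophenyl without moving the number beyond the scatter. That is thin ground, and it argues for no step beyond the scatter rather than for a step in either direction. Compound 3 is therefore expected near 9000 nM. The estimated range for compound 3 runs from 3000 nM to 27000 nM. The expected step is a 1.0-fold higher number from compound 2 to compound 3 (0.02 log units; within the scatter), within the scatter.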

Compound 3, half-maximal inhibitory concentration: 7900 nM
The estimate for compound 3 lay 1.1-fold (0.06 log units) above the measured number; the range from low to high includes it.
By their numbers in this assay, from the lowest: compounds 3, 2 and 1 (each within the scatter of the next).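

In this assay, among the compounds shown here, the first exchange of one aryl group for another on this nitrogen gives a 1.1-fold lower number from compound 2 to compound 3 (0.04 log units; within the scatter) and leaves 3-bromophenyl and 4-nitrophenyl not told apart, although the entering group carries hydrogen-bond acceptors and the leaving group carries none. For the compounds shown here, measured against the octyl group, the same position gives a 1.3-fold lower number from compound 1 to compound 3 (0.12 log units; within the scatter) and this step also stays within the scatter, so an alkyl chain and two differently substituted phenyl groups now all sit in one band on the shared core, with no pair among compounds 1, 2 and 3 separated. No supporting data at hand bear on the reason for this flat picture.

Still open, as far as these compounds go, is whether any group on this nitrogen moves the number beyond the scatter at all, for instance a short chain ending in an amine or a carboxylic acid, or a phenyl group carrying a hydroxyl. Also open, from the compounds shown here alone, is whether the bromine and nitro groups would read differently at the same place on the ring, which a pair such as 4-bromophenyl and 4-nitrophenyl would show.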